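Giving up a ring group on a carbonyl carbon

The compounds below may be only part of what the source reports. "The series", "measured", "known", "first", "only" and "open" are said of these compounds alone.

Compound 1 `CC[C@@H]1CC[C@@H](C(=O)N2CCN(C(C)=O)CC2)N1C(=O)C1=C(C(C)C)N2C(=N[C@@](C)(c3ccc(Cl)cc3)[C@H]2c2ccc(Cl)cc2)S1` gives 34 ug/mL
Compound 2 `CC[C@@H]1CC[C@@H](C(=O)N2CCN(C)[C@@H](C)C2)N1C(=O)C1=C(C(C)C)N2C(=N[C@@](C)(c3ccc(Cl)cc3)[C@H]2c2ccc(Cl)cc2)S1` gives 16 ug/mL

In a physicochemical assay for solubility, read by HPLC, in phosphate buffer, at pH 6.8 (a lower number here means a less soluble compound, a higher number a more soluble compound), compound 2 (16 ug/mL) stands lowest of the two measured compounds. Compound 3 `CC[C@@H]1CC[C@@H](C(=O)N2CCN(C(C)=O)[C@H](C)C2)N1C(=O)C1=C(C(C)C)N2C(=N[C@@](C)(c3ccc(Cl)cc3)[C@H]2c2ccc(Cl)cc2)S1` has not yet been measured. It differs from compound 2 on a carbonyl carbon (a group of 10 heavy atoms (7 carbon, 2 nitrogen, 1 oxygen; one six-membered non-aromatic ring with 2 hetero atoms) in place of a group of 8 heavy atoms (6 carbon, 2 nitrogen; one six-membered non-aromatic ring with 2 hetero atoms), on a carbonyl carbon), where 3,4-dimethylpiperazin-1-yl leaves. For the measured compounds named here, only one measured step bears on this change. That same group entered at that place in the modest drop (a 2.1-fold lower number from compound 1 to compound 2 (0.33 log units; beyond the scatter)), which lies just beyond the scatter. Compound 3 gives the group up again, so a small rise in the number is expected. One step is thin evidence, and the entering group has no measurement of its own. The expected move is a 1.9-fold higher number from compound 2 to compound 3 (0.27 log units; within the scatter) in this assay for this pair. The estimate for compound 3 is 30 ug/mL with an expected range from 14 ug/mL to 60 ug/mL.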

Compound 3, solubility: 25 ug/mL
Estimate against measurement, compound 3: 1.2-fold (0.08 log units) above; the range from low to high includes it.
By their numbers in this assay, from the lowest: compounds 2, 3 and 1 (each within the scatter of the next, the first and the last beyond it).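

In this assay, adding only a methyl on a saturated ring carbon gives a 1.4-fold lower number from compound 1 to compound 3 (0.13 log units; within the scatter), so this single change does not clearly separate the two compounds. Placing the group of compound 3 on the carbonyl carbon in place of 3,4-dimethylpiperazin-1-yl gives a 1.6-fold higher number from compound 2 to compound 3 (0.19 log units; within the scatter), which means that the earlier 2.1-fold lower number from compound 1 to compound 2 (0.33 log units; beyond the scatter) divides into two smaller steps, neither beyond the scatter on its own. No measurement shown here explains these differences.

The compounds shown leave open how 4-methylpiperazin-1-yl, which has no methyl on a saturated ring carbon, would read on the carbonyl carbon, and such a compound would test the two changes apart. On these data alone, how a morpholin-4-yl group would read at this place also remains open.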